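This account rests on a few compounds, and the source may have more. Where it says the series, first, only, none or still open, it means among the compounds named here.

Within the data shown here, in a functional assay on MIA PaCa-2 cells (Homo sapiens) for antiproliferative activity, read by MTT assay, with a stated time of 72 h (on this read-out lower numbers stand for stronger inhibition and higher numbers for weaker inhibition), compound 1 (`O=C1O/C(=C\Cn2cnc3c(F)nc(F)c(Cl)c32)C(OCc2ccccc2)=C1OCc1ccccc1`) gives 78000 nM, the highest of the single numbers so far. Compound 2 (`O=C1NC(O)(CCn2cnc3cc[nH]c3c2=O)C(OCc2ccccc2)=C1OCc1ccccc1`) gives 36600 nM, a lower number by a margin beyond the usual scatter. Compound 3 (`O=C1NC(O)(CCn2cnc3ccn(CCC4(O)NC(=O)C(OCc5ccccc5)=C4OCc4ccccc4)c3c2=O)C(OCc2ccccc2)=C1OCc1ccccc1`) gives 5700 nM; 4400 nM (2 entries) across its repeated entries. Compound 4 (`O=C1O/C(=C\Cn2cnc3ccnc(Cl)c32)C(OCc2ccccc2)=C1OCc1ccccc1`) keeps the rest of compound 1 and alters one part: a group of 10 heavy atoms (6 carbon, 3 nitrogen, 1 chlorine; one five-membered aromatic ring with 2 hetero atoms, one six-membered aromatic ring with 1 hetero atom) in place of a group of 12 heavy atoms (6 carbon, 3 nitrogen, 2 fluorine, 1 chlorine; one five-membered aromatic ring with 2 hetero atoms, one six-membered aromatic ring with 1 hetero atom), on a saturated chain carbon bound to a double-bonded chain carbon. The swap sits on a saturated chain carbon bound to a double-bonded chain carbon. Among the measured compounds shown here, no measured pair shows this change on its own, so only a modest expectation is possible. The estimated step of a 1.3-fold lower number from compound 1 to compound 4 (0.11 log units; within the scatter) is expected to stay within the scatter, with no firm direction. For compound 4 the estimated value is 60000 nM, with an expected range from 20000 nM to 150000 nM.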

Compound 4, half-maximal inhibitory concentration: > 100000 nM
Compound 4 was reported as a limit; the forecaster's own chance of this, stated with the estimate: 25%; at least 1.6-fold (0.22 log units) between middle value and limit.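

In this assay compound 4 gives > 100000 nM, which is a limit of the assay and not a number. Replacing the group with 2 fluorine atoms on this saturated chain carbon by one without fluorine gives an at least 1.2-fold higher number from compound 1 to compound 4 (0.10 log units; that floor lies within the scatter), so this change brought no gain in inhibition, though its floor alone cannot establish a real loss. How far the true value lies past that floor stays unknown: the limit of > 100000 nM in this assay, at which 1 of the 4 values shown sits.

The compounds shown leave open whether one fluorine atom alone would give a different number. They also leave open how a group carrying an amine or a carboxylic acid would behave at this place.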